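Exchanging the Outer Ring: What to Expect for Compound 3

This account rests on a few compounds, and the source may have more. Where it says the series, first, only, none or still open, it means among the compounds named here.

Of the compounds shown here, two have been measured in an assay on cells for agonist activity at probable G-protein coupled receptor 34 (Mus musculus), with a stated time of 1 h; a lower number here means a smaller maximal response, a higher number a larger maximal response. Compound 1 `N[C@@H](COP(=O)(O)OCCCOC(=O)CCc1ccccc1OCc1cccc(Oc2ccccc2Cl)c1)C(=O)O` gives 19.8%. Going by the values given here, compound 2 `N[C@@H](COP(=O)(O)OCCCOC(=O)CCc1ccccc1OCc1cccc(Oc2ccc(I)cc2)c1)C(=O)O` gives 19.1%; the only measured step, a number 0.7 percentage points lower from compound 1 to compound 2 (within the scatter), lies within the scatter, so compound 2 sits together with compound 1 and the two numbers cannot be told apart. The unmeasured compound 3 `CC(C)(C)c1cccc(Oc2cccc(COc3ccccc3CCC(=O)OCCCOP(=O)(O)OC[C@H](N)C(=O)O)c2)c1` differs from compound 2 in a single place: 3-(tert-butyl)phenyl in place of 4-iodophenyl on an oxygen on an aromatic ring. Among the compounds with values here, the one measured step bears on this change only loosely, since it too exchanged the ring on that oxygen for another one, and it left the maximal response essentially where it was. Nothing in the two measured values points to a shift beyond the scatter for a further exchange of the ring on that oxygen, so a step of about a number 0.9 percentage points higher from compound 2 to compound 3 (within the scatter) is expected, with no preferred direction. On that basis compound 3 is estimated to give 20% in this assay, with a likely range from 8% to 34%.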

Compound 3, largest response reached (Emax), in percent of the reference or control that the assay uses: 19.9%
Beside the measured number, compound 3's estimate is 0.1 percentage points above it, and the stated range covers the measured number.
By their numbers in this assay, from the lowest: compounds 2, 1 and 3 (each within the scatter of the next).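

In this assay, the exchange gives a number 0.8 percentage points higher from compound 2 to compound 3 (within the scatter), and replacing the other ring gives a number 0.1 percentage points higher from compound 1 to compound 3 (within the scatter), so 2-chlorophenyl, 4-iodophenyl and 3-(tert-butyl)phenyl on this oxygen cannot be told apart. Going by these compounds alone, what the earlier compounds did not show is that this holds for a group with no halogen at all: the ring substituent here is carbon only, and the group as a whole has 10 heavy atoms where 4-iodophenyl has 7. Nothing among the data shown explains why these three rings give such closely matching maximal responses.

Still open is whether this tolerance extends to a ring carrying an amine or a carboxylic acid, or to a longer alkyl chain on that oxygen in place of the ring, since all three groups shown are phenyl rings with a single halogen or carbon-only substituent. The three compounds also share the rest of the core, so they say nothing about how a change elsewhere in the molecule would move the response.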